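Cyclohexyl Acid Amide Tested Against Endoplasmic Reticulum Aminopeptidase 2

This account rests on a few compounds, and the source may have more. Where it says the series, first, only, none or still open, it means among the compounds named here.

For compound 1 `COC(=O)C(C)(C)NC(=O)c1cc(F)cc2cc(-c3ccc(Cl)cc3)oc12` the result in an assay on isolated protein for inhibition of endoplasmic reticulum aminopeptidase 2 (Homo sapiens) (on this read-out lower numbers stand for stronger inhibition and higher numbers for weaker inhibition), is "not determined" (no result reported). Compound 2 `O=C(NC1(C(=O)O)Cc2ccccc2C1)c1cc(F)cc2cc(-c3ccc(Cl)cc3)oc12` shares the same core; in this assay compound 2 gives > 30000 nM, which is a limit of the assay and not a number. Compound 1 thus stands beside the limit of > 30000 nM in this assay, at which 1 of the 2 values shown sits, with no number of its own. Compound 3 `O=C(NC1(C(=O)O)CCCCC1)c1cc(F)cc2cc(-c3ccc(Cl)cc3)oc12` differs from compound 1 by 1-carboxycyclohexyl in place of 1-(methoxycarbonyl)-1-methylethyl on an amide-type nitrogen. No step between measured compounds is shown, so the account expects weak inhibition for compound 3, with a fair chance that this assay again returns a limit. Compound 3 is estimated at 20000 nM, expected between 3000 nM and 60000 nM.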

Compound 3, half-maximal inhibitory concentration: > 30000 nM
Compound 3 gave a limit, no number; the forecaster's own chance of this, stated with the estimate: 60%; at least 1.5-fold (0.17 log units) between middle value and limit.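

In this assay compound 3 gives > 30000 nM, a limit and not a number. Compound 1 has no number either, so no step can be read between compound 1 and compound 3. The compounds shown leave open whether any change on the amide-type nitrogen alters inhibition.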